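This account rests on a few compounds, and the source may have more. Where it says the series, first, only, none or still open, it means among the compounds named here.

Measured so far:
compound 1, `CCCCOc1ccc(S(=O)(=O)N2CCCC[C@H]2CC(=O)N[C@@H]2CCCc3cc(CNC(C)(C)C)ccc32)cc1`, gives 590 nM
compound 2, `CC(C)(C)NCc1ccc2c(c1)CCC[C@H]2NC(=O)C[C@@H]1CCCCN1S(=O)(=O)c1cccc(Cl)c1`, gives 73 nM
compound 3, `CC(C)(C)CNCc1ccc2c(c1)CCC[C@H]2NC(=O)C[C@@H]1CCCCN1S(=O)(=O)c1cccc(C(F)(F)F)c1`, gives 230 nM

All three were tested in a functional assay for inhibition of B1 bradykinin receptor (Homo sapiens), read by calcium flux; a lower number here means a stronger inhibitor, a higher number a weaker inhibitor. Compound 3 stands second highest of the three numbers: compound 1 gives a higher number and compound 2 a lower one, both gaps beyond the scatter. Compound 4, `O=C(C[C@@H]1CCCCN1S(=O)(=O)c1cccc(C(F)(F)F)c1)N[C@@H]1CCCc2cc(CN3CCC3)ccc21`, is not yet measured. It differs from compound 3 in one place: azetidin-1-yl in place of neopentylamino on a saturated chain carbon bound to an aromatic carbon. Among the measured compounds shown here, the only step measured in one place is an 8.1-fold lower number from compound 1 to compound 2 (0.91 log units; beyond the scatter), and that step changes the group on the sulfonyl sulfur, not the amine at this place. For the measured compounds named here, no measured step touches the change from compound 3 to compound 4, so its direction is open. The number for compound 4 is therefore expected close to that of compound 3, with a wide range, a 1.3-fold higher number from compound 3 to compound 4 (0.12 log units; within the scatter). The estimate for compound 4 is 300 nM, between 70 nM and 1300 nM.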

Compound 4, half-maximal inhibitory concentration: 4300 nM
Beside the measured number, compound 4's estimate is 14-fold (1.16 log units) below it, outside the stated range (above it).
By their numbers in this assay, from the lowest: compound 2; then compound 3; then compound 1; then compound 4.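

In this assay, the group at this place, on a saturated chain carbon bound to an aromatic carbon, strongly affects the result: azetidin-1-yl in place of neopentylamino gives a 19-fold higher number from compound 3 to compound 4 (1.27 log units; beyond the scatter) in this series. The earlier single-place step changed only the group on the sulfonyl sulfur, so it could not show this. No measurement shown explains the change.

This swap adds a ring, removes a hydrogen-bond donor and lowers the heavy-atom count all at once, so these cannot be separated. A pyrrolidine, a piperidine or an open-chain dimethylamino group at this place could help pull them apart.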